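The source may report more compounds than this note shows. Statements on the series, on what has been measured and on what is new or still open speak of the compounds shown alone.

The measured compounds:
Compound 1 `Cc1cc(C)cc(-c2cncc(-c3nc4cc(C)cc(C)c4[nH]3)c2N2CCC(N)CC2)c1`, which in a functional assay on CHO-K1 cells for agonist activity at somatostatin receptor type 2 (Homo sapiens), read by cAMP accumulation, with a stated time of 30 min (on this read-out higher numbers stand for an effect only at larger amounts of compound and lower numbers for an effect already at smaller amounts), gives 0.013 nM.
Compound 2 `Cc1cc(C)cc(-c2cncc(-c3nc4cc(Cl)ccc4[nH]3)c2N2CCC(N)CC2)c1`, which in this assay gives 0.015 nM.
Compound 3 `Cc1cc(C)cc(-c2cncc(-c3nc4cc(F)ccc4[nH]3)c2N2CCC(N)CC2)c1`, which in this assay gives 0.013 nM.

Among the measured compounds shown here, compound 3 stands level with compound 1 at the digits given, the two together the lowest of the three numbers; the only measured step, a 1.2-fold lower number from compound 2 to compound 3 (0.06 log units; within the scatter), lies within the scatter, so the three compounds cannot be ordered against one another on these data.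

Compound 4 `Cc1cc(C)cc(-c2cncc(-c3nc4cc(C)ccc4[nH]3)c2N2CCC(N)CC2)c1` differs from compound 3 in one place: methyl in place of fluoro on an aromatic carbon. For the measured compounds named here, only one measured step touches the same position, and it, a 1.2-fold lower number from compound 2 to compound 3 (0.06 log units; within the scatter), showed no change beyond the scatter; the values of compound 1 and compound 3, which carry methyl and fluoro on that ring, also show no difference at the digits given. Going by the values given here, no measured step therefore points to a change beyond the scatter, and the expected step is no change at the digits printed from compound 3 to compound 4 (within the scatter). Compound 4 is accordingly estimated at 0.013 nM in this assay, with a range from 0.006 nM to 0.03 nM.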

Compound 4, half-maximal effective concentration: 0.013 nM
Compound 4: middle estimate and measured number agree at the digits printed, and the stated range covers the measured number.
By their numbers in this assay, from the lowest: compounds 1, 3, 4 and 2 (each within the scatter of the next).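

In this assay, methyl in place of fluoro gives no change at the digits printed from compound 3 to compound 4 (within the scatter), and methyl in place of chloro gives a 1.2-fold lower number from compound 2 to compound 4 (0.06 log units; within the scatter), so three different groups have now been compared at this place on the six-membered aromatic ring without any step leaving the scatter. Among the compounds shown here, the earlier compounds had offered only the step between the two halogens; the result extends this flat reading to a carbon-bearing group. Hydrogen in place of methyl on an aromatic carbon of the same ring gives no change at the digits printed from compound 1 to compound 4 (within the scatter), so the second methyl of compound 1 also shows no effect here, and nothing at hand explains these results.

The compounds shown leave open whether a carboxylic acid, an amine or a longer chain at this place would shift the number beyond the scatter. They also leave open what plain hydrogen there would give.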